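From dimethylamino to isopropylamino on a shared core

The compounds below may be only part of what the source reports. "The series", "measured", "known", "first", "only" and "open" are said of these compounds alone.

Compound 1 `CN(C)C(=O)/C=C1\CCc2c(F)cc(F)cc21`: 100 mg/kg
Compound 2 `Cc1cccc2c1/C(=C/C(N)=O)CC2`: 56 mg/kg

In a functional assay on the whole organism with Mus musculus as the target, in the rotarod test (on this read-out lower numbers stand for an effect already at smaller amounts and higher numbers for an effect only at larger amounts of compound), compound 1 gives 100 mg/kg and compound 2 gives 56 mg/kg, and these two values lie within the usual scatter of each other. Within the data shown here, neither compound can therefore be ranked over the other, and compound 1 stands level with the only other measured compound.

Compound 3 `CC(C)NC(=O)/C=C1\CCc2c(F)cc(F)cc21` keeps the core of compound 1 but carries isopropylamino in place of dimethylamino on a carbonyl carbon. Among the measured compounds shown here, no measured step shows what this exchange does in this assay, so the estimate stays close to compound 1 at 100 mg/kg. The expected 1.3-fold lower number from compound 1 to compound 3 (0.10 log units; within the scatter) lies within the scatter. For compound 3 the estimated value is 80 mg/kg with an expected range from 40 mg/kg to 160 mg/kg.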

Compound 3, dose for half-maximal effect: 76 mg/kg
Compound 3: the middle estimate sits 1.1-fold (0.02 log units) above what was measured, within the range that was stated.
By their numbers in this assay, from the lowest: compounds 2, 3 and 1 (each within the scatter of the next).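

In this assay, among these compounds, isopropylamino in place of dimethylamino on a carbonyl carbon gives a 1.3-fold lower number from compound 1 to compound 3 (0.12 log units; within the scatter), the first step that can be read at this position. The exchange brings in a hydrogen-bond donor, the amide hydrogen, and one more heavy atom, yet compound 3 stays level with compound 1 on the shared core. At this position, then, the read-out does not separate these two groups, and a secondary amide serves as well as a tertiary one here. Nothing measured alongside these values offers an explanation for this result.

Still open, from the compounds shown here alone, is whether a ring amine such as morpholine or piperidine, a longer chain such as n-butylamino, or a carboxylic acid at this carbonyl carbon would give a step beyond the scatter. Going by these compounds, whether the same exchange would stay as small on the core of compound 2 also remains open.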